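The compounds below may be only part of what the source reports. "The series", "measured", "known", "first", "only" and "open" are said of these compounds alone.

Measured so far in a functional assay on DU-145 cells (Homo sapiens) for inhibition, read by trypan blue exclusion, with a stated time of 96 h; on this read-out lower numbers stand for stronger inhibition of growth and higher numbers for weaker inhibition of growth:

- compound 1 `O=C(/C(=C\c1ccccc1OCc1ccccc1)SCc1ccc(F)cc1)c1ccc(Cl)cc1`: 1000 nM
- compound 2 `O=C(/C(=C\c1ccccc1OCc1ccccc1)S(=O)(=O)Cc1ccc(F)cc1)c1ccc(Cl)cc1`: 10000 nM
- compound 3 `COc1cc(OC)c(/C=C(/SCc2ccc(F)cc2)C(=O)c2ccc(Cl)cc2)c(OC)c1`: 10000 nM

Compound 1 and compound 2 share a core and differ only by (4-fluorobenzyl)sulfonyl in place of (4-fluorobenzyl)sulfanyl on a double-bonded chain carbon bound to a carbonyl carbon and a double-bonded chain carbon. That change gave a 10-fold higher number from compound 1 to compound 2 (1.00 log units; beyond the scatter). Compound 3 carries a different core; how its core differs from that of compound 1 is not broken down here. In this assay compound 3 gives 10000 nM, which is level with compound 2 at the digits recorded, and stands against compound 1 by a step beyond the scatter.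

Compound 4 `COc1cc(OC)c(/C=C(\C(=O)c2ccc(Cl)cc2)S(=O)(=O)Cc2ccc(F)cc2)c(OC)c1` is not yet measured. It is derived from compound 3 by (4-fluorobenzyl)sulfonyl in place of (4-fluorobenzyl)sulfanyl on a double-bonded chain carbon bound to a carbonyl carbon and a double-bonded chain carbon, the same change as from compound 1 to compound 2, at the same place. On the core of compound 1 this change gave a 10-fold higher number from compound 1 to compound 2 (1.00 log units; beyond the scatter). If the same size of step carries over to the core of compound 3, compound 4 is expected to move by about a 4.0-fold higher number from compound 3 to compound 4 (0.60 log units; beyond the scatter) from compound 3. Since compound 3 already sits at the higher of the numbers seen, the value of compound 4 may come out as a limit rather than a number. The estimate for compound 4 in this assay is 40000 nM, with a range from 8000 nM to 200000 nM.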

Compound 4, concentration for 50% growth inhibition: 25000 nM
The estimate for compound 4 lay 1.6-fold (0.20 log units) above the measured number, within the range that was stated.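

The change from (4-fluorobenzyl)sulfanyl to (4-fluorobenzyl)sulfonyl again gives a higher number in this assay, with a 2.5-fold higher number from compound 3 to compound 4 (0.40 log units; beyond the scatter), so the direction of the step holds on both cores shown. Its size does not carry over unchanged: the same change on two cores in this assay, a 10-fold higher number (1.00 log units; beyond the scatter) from compound 1 to compound 2 and a 2.5-fold higher number (0.40 log units; beyond the scatter) from compound 3 to compound 4, 4.0-fold (0.60 log units) apart, beyond the scatter of two such steps. Going by these compounds alone, with only two pairs, this shows that a step measured on one core gives the direction but not a dependable size on the other, and it does not show which difference between the cores goes with the larger step or how the change would behave on a further core.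

The compounds shown leave open whether an amine or a carboxylic acid in place of the (4-fluorobenzyl)sulfanyl, on a double-bonded chain carbon bound to a carbonyl carbon and a double-bonded chain carbon, would give a lower or a higher number. Also open, on these data alone, is whether the same change would move the number in the same direction on a core carrying a longer chain in place of the methoxy groups of compound 3.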